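The compounds below may be only part of what the source reports. "The series", "measured", "known", "first", "only" and "open" are said of these compounds alone.

Compound 1, `CCCOc1ccc2oc(/C=C/[S+](C)[O-])cc(=O)c2c1`, gives 1100 nM in a functional assay on A549 cells (Homo sapiens) for cytotoxicity, with a stated time of 48 h; a lower number here means a stronger inhibitor, a higher number a weaker inhibitor; that is the lowest of the three numbers measured, though its neighbors sit within the usual scatter. Compound 2, `Cc1ccc2oc(/C=C/[S+](C)[O-])cc(=O)c2c1`, gives 1700 nM, and compound 3, `CCCC(=O)Oc1ccc2oc(/C=C/[S+](C)[O-])cc(=O)c2c1`, gives 2200 nM. The steps are a 1.5-fold higher number from compound 1 to compound 2 (0.19 log units; within the scatter), a 2.0-fold higher number from compound 1 to compound 3 (0.30 log units; within the scatter) and a 1.3-fold higher number from compound 2 to compound 3 (0.11 log units; within the scatter), none beyond the scatter. Compound 4, `C[S+]([O-])/C=C/c1cc(=O)c2cc(Br)ccc2o1`, differs from compound 1 by bromo in place of propoxy on an aromatic carbon. The step from compound 1 to compound 2 bears most on this, since it likewise swaps the propoxy group for a small substituent on the same aromatic carbon and stays within the scatter. Compound 4 is therefore expected to show a 1.4-fold higher number from compound 1 to compound 4 (0.13 log units; within the scatter), a step within the scatter, with an estimated 1500 nM and a range from 600 nM to 4000 nM.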

Compound 4, half-maximal inhibitory concentration: 1100 nM
Compound 4: the middle estimate sits 1.4-fold (0.13 log units) above what was measured; measured number inside the range.
By their numbers in this assay, from the lowest: compounds 1, 4, 2 and 3 (each within the scatter of the next).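

In this assay, bromo in place of propoxy on this aromatic carbon gives no change at the digits printed from compound 1 to compound 4 (within the scatter). The other two comparisons show a 2.0-fold lower number from compound 3 to compound 4 (0.30 log units; within the scatter) and a 1.5-fold lower number from compound 2 to compound 4 (0.19 log units; within the scatter), so bromo joins propoxy, methyl and (propylcarbonyl)oxy as groups that this position holds without any step beyond the scatter. Nothing available offers a reason for this flat picture. From the compounds shown here alone, whether an amine or a carboxylic acid on this carbon would step beyond the scatter remains open, as does the outcome for a much longer chain.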